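This account rests on a few compounds, and the source may have more. Where it says the series, first, only, none or still open, it means among the compounds named here.

Measured so far:
compound 1, `CCCn1c(=O)c2nc([C@@H]3CC4CCC3C4)[nH]c2n(CCC)c1=O`: 3.8 nM
compound 2, `CCCn1c(=O)c2nc(-c3ccco3)[nH]c2n(CCC)c1=O`: 560 nM
compound 3, `CCCn1c(=O)c2nc(CC(C)(C)C)[nH]c2n(CCC)c1=O`: 49 nM

In an assay on cell membranes for binding affinity to adenosine receptor A1 (Cavia porcellus), read by radioligand binding (a higher number here means a weaker inhibitor, a lower number a stronger inhibitor), compound 3 gives 49 nM, the second highest of the three numbers. Its position is framed by two steps, each beyond the scatter: an 11-fold lower number from compound 2 to compound 3 (1.06 log units; beyond the scatter) and a 13-fold higher number from compound 1 to compound 3 (1.11 log units; beyond the scatter). Compound 4, `CCCn1c(=O)c2nc(CC3CC3)[nH]c2n(CCC)c1=O`, differs from compound 3 in one place: cyclopropyl in place of tert-butyl on a saturated chain carbon bound to an aromatic carbon.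

All three measured steps change the group on the aromatic carbon of the shared core, so all bear on this change, though none of them is the same kind of exchange. The largest is a 150-fold higher number from compound 1 to compound 2 (2.17 log units; beyond the scatter), where a five-membered aromatic ring with one hetero atom replaced two saturated carbon rings. The step most alike in kind is a 13-fold higher number from compound 1 to compound 3 (1.11 log units; beyond the scatter), where a saturated group without a ring replaced the larger saturated two-ring group and the number went up. Here the saturated, ring-free tert-butyl gives way to a smaller cyclopropyl, and no measured step trades one small saturated group for another. On that basis a modest upward step is expected, a 1.6-fold higher number from compound 3 to compound 4 (0.21 log units; within the scatter), possibly not beyond the scatter. Compound 4 is therefore estimated at 80 nM, with a range from 25 nM to 250 nM.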

Compound 4, inhibition constant: 120 nM
The estimate for compound 4 lay 1.5-fold (0.18 log units) below the measured number, and the stated range covers the measured number.
By their numbers in this assay, from the lowest: compound 1; then compound 3; then compound 4; then compound 2.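

In this assay, for the compounds shown here, the step of a 2.4-fold higher number from compound 3 to compound 4 (0.39 log units; beyond the scatter) is the first exchange made further out on the group, on a saturated chain carbon bound to an aromatic carbon, and it shows that the number responds beyond the scatter to a change at that place as well. Measured against the other groups on the aromatic carbon, cyclopropylmethyl gives a 4.7-fold lower number from compound 2 to compound 4 (0.67 log units; beyond the scatter) and also a 32-fold higher number from compound 1 to compound 4 (1.50 log units; beyond the scatter) and so the numbers of compound 3 and compound 4 both fall inside the span set by compound 1 and compound 2. A saturated carbon ring does not by itself bring the lower number: compound 4 carries one and stands above the ring-free compound 3, while compound 1, with its two rings, stands lowest of the four.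

Nothing shown here gives a measured reason for these differences.

From the compounds shown here alone, whether a longer chain such as n-butyl would follow neopentyl or cyclopropylmethyl remains open. So does the effect of an amine or a hydroxyl on the saturated chain carbon, and of a cyclopentyl ring placed directly on the aromatic carbon.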